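Amide aryl variation on the shared core: compound 4

The source may hold more compounds than are shown below. What is called first, only, known or untested is meant among the compounds shown, and "the series" means these compounds.

Three amides share the core of compound 1 `O=C(Nc1cccc(-c2oc3cc(-c4ccc(F)cc4)ccc3c(=O)c2O)c1)c1ccc(F)cc1` and differ only in the aryl group on the carbonyl carbon. In a functional assay on HeLa cells (Homo sapiens) for antiproliferative activity, read by CCK-8 assay, with a stated time of 72 h (a lower number here means a stronger inhibitor, a higher number a weaker inhibitor), compound 1 gives 5350 nM, compound 2 `Cc1ccc(C(=O)Nc2cccc(-c3oc4cc(-c5ccc(F)cc5)ccc4c(=O)c3O)c2)cc1` gives 6190 nM, and compound 3 `Cc1ccccc1C(=O)Nc1cccc(-c2oc3cc(-c4ccc(F)cc4)ccc3c(=O)c2O)c1` gives 11900 nM, the highest of the three numbers. The steps of a 2.2-fold higher number from compound 1 to compound 3 (0.35 log units; beyond the scatter) and a 1.9-fold higher number from compound 2 to compound 3 (0.28 log units; within the scatter) frame it. Compound 4 `O=C(Nc1cccc(-c2oc3cc(-c4ccc(F)cc4)ccc3c(=O)c2O)c1)c1ccc(C(F)(F)F)cc1` carries 4-(trifluoromethyl)phenyl in place of 2-methylphenyl on a carbonyl carbon, that is, a return to a 4-substituted phenyl of the kind found in compounds 1 and 2. The reversal of the step from compound 1 to compound 3 is the nearest guide, so a modest lower number is expected, as a 2.0-fold lower number from compound 3 to compound 4 (0.30 log units; within the scatter). Compound 4 is therefore estimated at 6000 nM, within 2500 nM to 14000 nM.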

Compound 4, half-maximal inhibitory concentration: 17400 nM
Estimate against measurement, compound 4: 2.9-fold (0.46 log units) below; the whole stated range lies below it.
By their numbers in this assay, from the lowest: compounds 1, 2, 3 and 4 (each within the scatter of the next, the first and the last beyond it).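

In this assay, a 4-substituted phenyl on the carbonyl carbon does not by itself bring back the numbers of compound 1 and compound 2: 4-(trifluoromethyl)phenyl in place of 2-methylphenyl gives a 1.5-fold higher number from compound 3 to compound 4 (0.17 log units; within the scatter) and leaves these two amides unseparated. Among the 4-substituted phenyl amides, the choice of group now counts, with a 2.8-fold higher number from compound 2 to compound 4 (0.45 log units; beyond the scatter) for trifluoromethyl in place of methyl and a 3.3-fold higher number from compound 1 to compound 4 (0.51 log units; beyond the scatter) for trifluoromethyl in place of fluoro, although methyl and fluoro themselves stayed within the scatter of each other. Nothing available here accounts for these steps.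

Open, on these data alone, is how an amine, a carboxylic acid or a chain longer than methyl on this phenyl would compare with compound 1.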